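Methoxy for Fluoro on a Cytotoxic Amide Series

A few compounds are considered here, and "the series" means these few. Any claim that something is new, unique, unknown or untested is made for them only; others in the source may bear on it.

Of the compounds shown here, three have been measured in a functional assay on DU-145 cells (Homo sapiens) for cytotoxicity, read by MTT assay, with a stated time of 48 h; a lower number here means a stronger inhibitor, a higher number a weaker inhibitor. Compound 1 `COc1ccc(-c2cc(C(=O)Nc3nc4ccc(F)cc4s3)nc3cc(-c4ccccc4)nn23)cc1OC` gives 18600 nM. Compound 2 `COc1ccc2nc(NC(=O)c3cc(-c4ccc(OC)c(OC)c4)n4nc(-c5ccccc5)cc4n3)sc2c1` gives 14000 nM. Compound 3 `Cc1cc2nc(NC(=O)c3cc(-c4ccc(F)cc4)n4nc(-c5ccccc5)cc4n3)sc2cc1C` gives 12900 nM. The three values lie close together, and none of the gaps between them passes beyond the usual scatter of repeated measurements, so no order of strength can be read from them.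

Compound 1 and compound 2 differ in one place: methoxy in place of fluoro on an aromatic carbon. This change gave a 1.3-fold lower number from compound 1 to compound 2 (0.12 log units; within the scatter).

Compound 4 `COc1ccc(-c2cc(C(=O)Nc3nc4cc(C)c(C)cc4s3)nc3cc(-c4ccccc4)nn23)cc1` has not yet been measured. It differs from compound 3 in one place: methoxy in place of fluoro on an aromatic carbon. How compound 3 differs from compound 1 in its core is not broken down here. The change from compound 3 to compound 4 is the same kind of change as that from compound 1 to compound 2, but it sits at a different place: in compound 2 the methoxy sits on an aromatic carbon of a six-membered aromatic ring of carbon only, part of a fused or bridged system of two rings, meta to a fused ring and para to a fused ring, while in compound 4 it sits on an aromatic carbon of a six-membered aromatic ring of carbon only, para to a large group.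

The step from compound 3 to compound 4 is expected to be a 1.2-fold lower number from compound 3 to compound 4 (0.07 log units; within the scatter), resting on the earlier step of a 1.3-fold lower number from compound 1 to compound 2 (0.12 log units; within the scatter), which stayed within the scatter. Compound 4 is thus estimated at 11000 nM, with a range from 5000 nM to 25000 nM.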

Compound 4, half-maximal inhibitory concentration: 12300 nM
For compound 4 the middle estimate is 1.1-fold (0.05 log units) below the measured one, and the stated range covers the measured number.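

In this assay, putting methoxy in place of fluoro, here as 4-fluorophenyl to 4-methoxyphenyl, gave a 1.0-fold lower number from compound 3 to compound 4 (0.02 log units; within the scatter). Set beside the same change on the other core, the two steps do not differ: the same change on two cores in this assay, a 1.3-fold lower number (0.12 log units; within the scatter) from compound 1 to compound 2 and a 1.0-fold lower number (0.02 log units; within the scatter) from compound 3 to compound 4, 1.3-fold (0.10 log units) apart, within the scatter of two such steps. This shows that on these two cores, with the change sitting at two different places, the swap behaved alike and left the number within the usual scatter each time, but it does not show that methoxy makes these compounds stronger or weaker inhibitors, and two small steps are too little to predict the swap on a further core.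

The compounds shown leave open whether a different group in the same place, such as an amine or a carboxylic acid, would give a step that rises beyond the scatter, since fluoro and methoxy are the only two groups compared there. They also leave open whether the close agreement between the two steps would hold on other cell types, as every number here comes from one cytotoxicity read-out on one cell line.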